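A 2-Fluorobenzyl Group on a Phenolic Oxygen

The source may report more compounds than this note shows. Statements on the series, on what has been measured and on what is new or still open speak of the compounds shown alone.

Of the compounds shown here, three sharing one core have been tested in an ADME assay on KB cells (Homo sapiens) for cytotoxicity; on this read-out higher numbers stand for an effect only at larger amounts of compound and lower numbers for an effect already at smaller amounts. Compound 1, `CCCCOc1c(OC)c(OC)cc2c1C(=O)[C@]1(OC)C=C[C@H]2N(C(=O)OC)N1C(=O)OC`, gives > 300 ug/mL in this assay, which is a limit rather than a number. Compound 2, `COc1cc2c(c(O)c1OC)C(=O)[C@]1(OC)C=C[C@H]2N(C(=O)OCC(C)C)N1C(=O)OCC(C)C`, likewise gives only the limit > 300 ug/mL in this assay. Among the compounds with values here, compound 3, `CCCCOc1c(OC)c(OC)cc2c1C(=O)[C@]1(OC)C=C[C@H]2N(C(=O)OCC)N1C(=O)OCC`, is the only compound with a number, giving 76 ug/mL in this assay. Within the data shown here, compound 2 therefore stands at the limit of > 300 ug/mL in this assay, at which 2 of the 3 values shown sit, and no measured step leads to or from it, since every other compound differs from it in more than one place.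

Compound 4, `COc1cc2c(c(OCc3ccccc3F)c1OC)C(=O)[C@]1(OC)C=C[C@H]2N(C(=O)OCC(C)C)N1C(=O)OCC(C)C`, differs from compound 2 in one place: 2-fluorobenzyl in place of hydrogen on an oxygen on an aromatic ring. Compound 1 and compound 3 also carry a chain on that oxygen, but both differ from compound 2 elsewhere as well, so no single-step comparison exists. The step of an at least 1.5-fold lower number from compound 2 to compound 4 (0.17 log units; that floor lies within the scatter) is expected to be modest, toward an effect at somewhat smaller amounts, and may well stay within the scatter. Compound 4 is expected to give about 200 ug/mL in this assay, within a range from 60 ug/mL to 400 ug/mL.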

Compound 4, concentration for half-maximal effect: 109 ug/mL
The estimate for compound 4 lay 1.8-fold (0.26 log units) above the measured number; low and high end bracket the measured number.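

In this assay, putting 2-fluorobenzyl in place of hydrogen on an oxygen on an aromatic ring gives an at least 2.7-fold lower number from compound 2 to compound 4 (0.43 log units; beyond the scatter). Within the data shown here, this is the first change at this oxygen that can be read on its own, since the earlier compounds with a chain there also differ elsewhere. Compound 2 gives > 300 ug/mL, which is a limit and not a number, and the true size of the step stays unknown because the comparison starts from that limit: the limit of > 300 ug/mL in this assay, at which 2 of the 4 values shown sit.

The compounds shown leave open whether the change in the read-out depends on the fluorine, on the aromatic ring, or on any group placed on this oxygen; a plain benzyl or a butyl chain on the core of compound 2 would separate these. On these data alone, whether a group carrying an amine would behave alike at this oxygen also remains open.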